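Series notes: cytotoxicity at the limit, oxazole step pending

This account rests on a few compounds, and the source may have more. Where it says the series, first, only, none or still open, it means among the compounds named here.

Compound 3 `CCOCCNc1nc(N)nc2ccn(Cc3ccccn3)c12` shares its core with compound 1 `CCCCNc1nc(N)nc2ccn(Cc3ccccc3)c12` and compound 2 `CCCCNc1nc(N)nc2ccn(Cc3ccncc3)c12`. In an ADME assay on HEK293 cells (Homo sapiens) for cytotoxicity, read by ATP content, with a stated time of 6 h (on this read-out higher numbers stand for lower toxicity in this test and lower numbers for higher toxicity in this test), compound 1 reaches only the limit of the assay, > 24000 nM. Compound 2 likewise reaches only a limit in this assay, > 24000 nM. Compound 3 stands at a limit as well in this assay, > 24000 nM, so no number places it relative to its neighbours. The whole set sits at the limit of > 24000 nM in this assay, at which 3 of the 3 values shown sit. Among the measured compounds shown here, the one step between measured neighbours, a step that the two limits leave unreadable from compound 1 to compound 2, cannot be read for the same reason. Compound 4 `CC(C)c1cc(CNc2nc(N)nc3ccn(Cc4ccccn4)c23)no1` differs from compound 3 by 5-isopropyl-1,2-oxazol-3-yl in place of ethoxymethyl on a saturated chain carbon bound to a nitrogen on an aromatic ring. For the measured compounds named here, no measured step touches this change, and the single recorded step is unreadable, so the expectation for compound 4 in this assay rests on the limits alone: compound 4 is expected to sit at the limit too, with an expected step that the limit leaves unreadable from compound 3 to compound 4. For compound 4 the estimate in this assay is 30000 nM, within 12000 nM to 80000 nM.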

Compound 4, half-maximal cytotoxic concentration: > 24000 nM
Compound 4: a limit, no number; the forecaster's own chance of this, stated with the estimate: 70%; the middle value does not contradict the limit.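

No step can be read between compound 3 and compound 4, since both give only a limit in this assay. The compounds shown leave open whether any of these changes shifts cytotoxicity, and the whole set gives no number to compare: the limit of > 24000 nM in this assay, at which 4 of the 4 values shown sit.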